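A few compounds are considered here, and "the series" means these few. Any claim that something is new, unique, unknown or untested is made for them only; others in the source may bear on it.

Within the data shown here, in a functional assay on L6 cells (Rattus norvegicus) for cytotoxicity (on this read-out lower numbers stand for stronger inhibition and higher numbers for weaker inhibition), compound 2 `N=C(N)c1ccc(-c2ccc(-c3ccc(C(=N)N)cc3)cc2)cc1` gives 22100 nM, the higher of the two numbers so far, while compound 1 `N=C(N)c1ccc(-c2ccc(-c3ccc(C(=N)N)cc3)c(F)c2)cc1` gives 6400 nM. Compound 3 `N=C(N)c1ccc(-c2ccc(-c3ccc(C(=N)N)cc3)c(C(F)(F)F)c2)cc1` is derived from compound 2 with trifluoromethyl in place of hydrogen on an aromatic carbon. Among the measured compounds shown here, the one measured step that bears on this change is the exchange of fluoro for hydrogen, a 3.5-fold higher number from compound 1 to compound 2 (0.54 log units; beyond the scatter). Read in reverse, that step suggests a similarly modest move towards a lower number in this assay, though a single step is thin evidence. The expected change is a 2.8-fold lower number from compound 2 to compound 3 (0.44 log units; beyond the scatter). For compound 3 the estimated value is 8000 nM, with an expected range of 2500 nM to 25000 nM.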

Compound 3, half-maximal inhibitory concentration: 9400 nM
For compound 3 the middle estimate is 1.2-fold (0.07 log units) below the measured one; the measured number falls inside the stated range.
By their numbers in this assay, from the lowest: compounds 1 and 3 (each within the scatter of the next); then compound 2.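

In this assay, trifluoromethyl on this aromatic carbon gives a 2.4-fold lower number from compound 2 to compound 3 (0.37 log units; beyond the scatter), so fluoro is no longer the only group shown to differ from hydrogen at this position. The exchange between the two substituents gives a 1.5-fold higher number from compound 1 to compound 3 (0.17 log units; within the scatter), which leaves them undistinguished on this read-out. Nothing available here accounts for either step.

The compounds shown leave open whether a group without fluorine, such as methyl or an amine, would give a similar step at this position. They also leave open whether fluoro or trifluoromethyl would do so elsewhere on the shared core.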